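The compounds below may be only part of what the source reports. "The series", "measured", "known", "first", "only" and "open" are said of these compounds alone.

Compound 1 `CCOC(=O)c1c(-c2cccc(-c3ccccc3)c2)[nH]c2cc(OC)c(OC)cc2c1=O` was examined in an ADME assay on HEK293 cells (Homo sapiens) for cytotoxicity, read by luminescence, with a stated time of 72 h; on this read-out higher numbers stand for an effect only at larger amounts of compound and lower numbers for an effect already at smaller amounts. In that test compound 1 gives > 22000 nM, which is a limit of the assay rather than a number. Compound 2 `CCOC(=O)c1c(-c2cccc(OC)c2)[nH]c2cc(OC)c(OC)cc2c1=O` carries the change (methoxy in place of phenyl on an aromatic carbon). In this assay compound 2 gives > 22000 nM, again only a limit. The resulting step is a step that the two limits leave unreadable from compound 1 to compound 2. Compound 3 `CCOC(=O)c1c(-c2cccc(-c3ccccc3)c2)[nH]c2cc(OC)c(F)cc2c1=O` differs from compound 1 in its core by fluoro in place of methoxy on an aromatic carbon. In this assay compound 3 gives > 22000 nM, once more a limit. That step is a step that the two limits leave unreadable from compound 1 to compound 3. Compound 4 `CCOC(=O)c1c(-c2cccc(OC)c2)[nH]c2cc(OC)c(F)cc2c1=O` carries, from compound 3, the same change as compound 2 carries from compound 1, namely (methoxy in place of phenyl on an aromatic carbon). Because (the limit of > 22000 nM in this assay, at which 3 of the 3 values shown sit), the step is expected to be a step that the limit leaves unreadable from compound 3 to compound 4. For compound 4 the expected value in this assay is 30000 nM, most likely reported as a limit.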

Compound 4, half-maximal effective concentration: > 22000 nM
Compound 4 ended at the assay's limit; the forecaster's own chance of this, stated with the estimate: 85%; the middle value lies beyond the limit too.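

No new step can be read from compound 3 or compound 2 to compound 4, since all four compounds share one assay limit: the limit of > 22000 nM in this assay, at which 4 of the 4 values shown sit.

The compounds shown leave open at what concentration compound 1, compound 2, compound 3 or compound 4 would show an effect in this assay.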